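The source may report more compounds than this note shows. Statements on the series, on what has been measured and on what is new or still open speak of the compounds shown alone.

Within the data shown here, compound 3 `CCCC(C)n1nc(-c2cccs2)c(O)c(C2=NS(=O)(=O)c3cc(NS(C)(=O)=O)ccc3N2)c1=O` is one of three compounds measured so far in an in vitro ADME assay on microsomes from liver (Homo sapiens) for metabolic stability, tested at 5 uM; a higher number here means that the compound lasts longer, a lower number that the compound disappears faster. Compound 1 `CC(C)CCn1nc(-c2cccs2)c(O)c(C2=NS(=O)(=O)c3cc(S(C)(=O)=O)ccc3N2)c1=O` gives 0.0933 h in this assay, and compound 2 `CC(C)CCc1nn(CCC(C)C)c(=O)c(C2=NS(=O)(=O)c3cc(NS(C)(=O)=O)ccc3N2)c1O` gives 0.167 h in this assay. For compound 3 the result is only a limit of the assay, > 1 h, so that compound 3 has no number of its own and stands at the limit of what this kind of measurement reports, the point at which one of the three values shown sits (the limit of > 1 h in this assay, at which 1 of the 3 values shown sits). Compound 4 `CS(=O)(=O)Nc1ccc2c(c1)S(=O)(=O)N=C(c1c(O)c(-c3cccs3)nn(Cc3ccc(F)cc3)c1=O)N2` has not yet been measured. It differs from compound 3 in one place: 4-fluorobenzyl in place of 1-methylbutyl on an aromatic nitrogen. Among the measured compounds shown here, no step between measured compounds that differ in a single place is available, so the measured compounds give no guide to the size or direction of this change; it may be a step beyond the scatter in either direction or no step at all. Compound 4 is estimated to lie near 0.8 h, between 0.3 h and 2 h. That estimate means an expected step of an at least 1.2-fold lower number from compound 3 to compound 4 (0.09 log units; that floor lies within the scatter) downward from the limit, though the limit itself leaves its true size open.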

Compound 4, half-life: > 1 h
Compound 4: a limit, no number (the forecaster's own chance of this, stated with the estimate: 35%); middle value at least 1.2-fold (0.09 log units) away from the limit.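

Among these compounds, compound 3 and compound 4 both stand at a limit in this assay, so no step between them can be read: the limit of > 1 h in this assay, at which 2 of the 4 values shown sit. The compounds shown leave open how long each of the two actually lasts, and whether 4-fluorobenzyl in place of 1-methylbutyl changes the half-life at all.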